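Fluoro in place of nitro: notes on a small series

The compounds below may be only part of what the source reports. "The series", "measured", "known", "first", "only" and "open" are said of these compounds alone.

Measured in a functional assay on HUVEC cells (Homo sapiens) for antiproliferative activity, read by MTT assay, with a stated time of 48 h; a higher number here means a weaker inhibitor, a lower number a stronger inhibitor:
- compound 1 `Brc1cccc(/C=C/c2nnc(-c3ccc4c(c3)OCCO4)o2)c1`: 13500 nM
- compound 2 `Cc1ccc(/C=C/c2nnc(-c3ccc4c(c3)OCCO4)o2)cc1`: 45200 nM
- compound 3 `O=[N+]([O-])c1ccc(/C=C/c2nnc(-c3ccc4c(c3)OCCO4)o2)cc1`: 32100 nM

Compound 3, at 32100 nM, sits with compound 2 at the upper end of these numbers. Those two lie within the scatter of each other, while compound 1 gives a lower number than either.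

Compound 4 `Fc1ccc(/C=C/c2nnc(-c3ccc4c(c3)OCCO4)o2)cc1` carries fluoro in place of nitro on an aromatic carbon, para to a large group: fluoro in place of nitro on an aromatic carbon. Among the compounds with values here, no fluoro compound has been measured yet, so the expectation rests on two steps. The closer guide is a 1.4-fold lower number from compound 2 to compound 3 (0.15 log units; within the scatter), an exchange of one group for another at this same place, and it stays within the scatter. The other, a 3.3-fold higher number from compound 1 to compound 2 (0.52 log units; beyond the scatter), is modest but beyond the scatter. It replaces 3-bromophenyl with 4-methylphenyl, a wider change than the one here, so it mainly sets how wide the range should be.

In this assay, as far as these compounds go, no step beyond the scatter is expected, and the direction stays open. The expected step is a 1.1-fold lower number from compound 3 to compound 4 (0.03 log units; within the scatter). Compound 4 is estimated at 30000 nM, with an expected range of 15000 nM to 60000 nM.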

Compound 4, half-maximal inhibitory concentration: 4960 nM
For compound 4 the middle estimate is 6.0-fold (0.78 log units) above the measured one; measured number below the stated range.
By their numbers in this assay, from the lowest: compound 4; then compound 1; then compounds 3 and 2 (each within the scatter of the next).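

Within the data shown here, at this aromatic carbon, para to a large group, the choice of group matters more in this assay than the earlier compounds showed: fluoro in place of nitro gives a 6.5-fold lower number from compound 3 to compound 4 (0.81 log units; beyond the scatter) and is a clear departure from the exchange of methyl for nitro, which stayed within the scatter. Fluoro in place of methyl at the same place gives a 9.1-fold lower number from compound 2 to compound 4 (0.96 log units; beyond the scatter) and so sets fluoro apart from both earlier groups at this position, although those two cannot be separated from each other. The exchange of 3-bromophenyl for 4-fluorophenyl gives a 2.7-fold lower number from compound 1 to compound 4 (0.43 log units; beyond the scatter) as well, which leaves compound 4 with the lowest number of the series, beyond the scatter from all three other compounds.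

As far as these compounds go, it remains open whether this gain belongs to fluoro alone, as chloro, methoxy or an amine at this aromatic carbon would show, and the step from the 3-bromophenyl compound cannot separate the identity of the halogen from its place on the ring. Nothing among the available data accounts for the size of these steps.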